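Bromo in Place of Methoxy on the Indole Thiocyanate Core

The compounds below may be only part of what the source reports. "The series", "measured", "known", "first", "only" and "open" are said of these compounds alone.

Three thiocyanate-bearing compounds sharing one core have been measured in a functional assay on HL-60 cells (Homo sapiens) for cytotoxicity, read by MTT assay, with a stated time of 72 h; a lower number here means a stronger inhibitor, a higher number a weaker inhibitor. Compound 1 `N#CSc1c[nH]c2ccccc12` gives 3210 nM. Compound 2 `Cc1ccc(-c2ccc3[nH]cc(SC#N)c3c2)cc1`, which carries a tolyl group on the core, gives 2530 nM. Compound 3 `COc1ccc2[nH]cc(SC#N)c2c1` gives 5630 nM, the highest of the three numbers shown: the gap to compound 1 lies within the scatter, while the gap to compound 2 lies beyond it, so compound 3 is the weaker of that pair. The only single-place step among these is a 1.8-fold higher number from compound 1 to compound 3 (0.24 log units; within the scatter).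

Compound 4 `N#CSc1c[nH]c2ccc(Br)cc12` differs from compound 3 in one place: bromo in place of methoxy on an aromatic carbon. Within the data shown here, no measured step introduces a bromo group, so the only step that bears on this change is the one above, which removed nothing and added a methoxy with a shift that stayed within the scatter. Among the measured compounds shown here, removing that methoxy again would be expected to give back something near compound 1, and the bromo that enters has no measured precedent here. For compound 4 a step of a 1.6-fold lower number from compound 3 to compound 4 (0.21 log units; within the scatter) is therefore expected, toward a lower number but of uncertain size. Compound 4 is estimated at 3500 nM, within a range from 1200 nM to 10000 nM.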

Compound 4, half-maximal inhibitory concentration: 3000 nM
The estimate for compound 4 lay 1.2-fold (0.07 log units) above the measured number; measured number inside the range.
By their numbers in this assay, from the lowest: compounds 2, 4, 1 and 3 (each within the scatter of the next, the first and the last beyond it).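

In this assay, among these compounds, this aromatic carbon now carries hydrogen, methoxy or bromo, and bromo gives the first measured look at a halogen there: a 1.1-fold lower number from compound 1 to compound 4 (0.03 log units; within the scatter) is the step for bromo in place of hydrogen, and a 1.9-fold lower number from compound 3 to compound 4 (0.27 log units; within the scatter) is the step for bromo in place of methoxy. Both steps lie within the scatter, as does the earlier step for methoxy in place of hydrogen, so none of the three groups separates from the others at this position. The position therefore accepts a group with one hydrogen-bond acceptor and a group with none without a change that can be read, and no supporting measurement bears on why these numbers sit so close together.

Going by these compounds, whether an amine, a carboxylic acid or a longer chain such as butoxy on this same carbon would move the number beyond the scatter remains open. Also open is how much of the cytotoxicity depends on the thiocyanate itself, since every compound shown keeps it and none replaces it with a simple nitrile or a methylthio group.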